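The source may report more compounds than this note shows. Statements on the series, on what has been measured and on what is new or still open speak of the compounds shown alone.

Values so far in a functional assay on blood (Homo sapiens), with a stated time of 60 min, in the presence of a further agent that is not named here; a lower number here means that less compound is needed, a higher number that more compound is needed for the effect
compound 1 `CON(C)C(=O)C1(S(=O)(=O)c2ccc(Oc3ccc(OC(F)(F)F)cc3)cc2)CCC2(CCNCC2)C1` 3700 nM
compound 2 `O=C(O)C1(S(=O)(=O)c2ccc(Oc3ccc(OC(F)(F)F)cc3)cc2)CCC2(CCNCC2)C1` 1800 nM

Compound 2 has the lower of the two numbers (1800 nM). Compound 3 `COC(=O)C1(S(=O)(=O)c2ccc(Oc3ccc(OC(F)(F)F)cc3)cc2)CCC2(CCNCC2)C1` differs from it by methyl in place of hydrogen on an oxygen next to a carbonyl group, carboxy to methoxycarbonyl (methyl in place of hydrogen on an oxygen next to a carbonyl group). For the measured compounds named here, one measured step bears on this change, the modest 2.1-fold lower number from compound 1 to compound 2 (0.31 log units; beyond the scatter), where hydroxy replaced methoxy(methyl)amino on a carbonyl carbon. Losing the hydroxy again is therefore expected to give a similarly modest move to a higher number in this assay (a 1.7-fold higher number from compound 2 to compound 3 (0.22 log units; within the scatter)). For compound 3 the estimated value is 3000 nM with 1200 nM to 7500 nM as its range.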

Compound 3, half-maximal effective concentration: > 15000 nM
Compound 3 gave a limit, no number; the forecaster's own chance of this, stated with the estimate: 10%; at least 5.0-fold (0.69 log units) between middle value and limit.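

In this assay compound 3 gives only a limit, > 15000 nM, not a number. Methyl in place of hydrogen on this oxygen is therefore a larger change than the earlier pair suggested, with an at least 8.3-fold higher number from compound 2 to compound 3 (0.92 log units; beyond the scatter). Methoxy also compares poorly with methoxy(methyl)amino on the carbonyl carbon, with an at least 4.0-fold higher number from compound 1 to compound 3 (0.60 log units; beyond the scatter), so the order of lowest to highest number is carboxy, methoxy(methyl)amino, methoxy.

Going by these compounds, the true value of compound 3 remains open, so the full size of both steps is unknown. On these data alone, it is also open whether a primary amide or an ethyl ester at this position would fit this order.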